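This account rests on a few compounds, and the source may have more. Where it says the series, first, only, none or still open, it means among the compounds named here.

Compound 1 `O=C1C=C(NCc2ccccc2)C(=O)c2c1nc1n2[C@H]2OC[C@@H](O)[C@H]2OC1` carries a benzyl group on an amine nitrogen attached to the shared core. Within the data shown here, in a functional assay on MGC-803 cells (Homo sapiens) for inhibition, read by sulforhodamine B assay (a higher number here means a weaker inhibitor, a lower number a stronger inhibitor), compound 1 gives 2670 nM, the only measured number in this set. Compound 2 `O=C1C(NC2CCCC2)=CC(=O)c2c1nc1n2[C@H]2OC[C@@H](O)[C@H]2OC1` carries a cyclopentyl group on that nitrogen. In this assay compound 2 gives > 16000 nM, which is a limit of the assay rather than a number. Compound 1 therefore stands alone with a real value, while the limit of > 16000 nM in this assay, at which 1 of the 2 values shown sits, marks where the other compound sits. Compound 3 `CCOc1ccc(NC2=CC(=O)c3nc4n(c3C2=O)[C@H]2OC[C@@H](O)[C@H]2OC4)cc1` has not been measured; it differs from compound 1 in one place: 4-ethoxyphenyl in place of benzyl on an amine nitrogen. Among the measured compounds shown here, no step between two measured compounds exists to guide the expectation, so the direction is open; the swap of one aromatic group for another on the same nitrogen is expected to shift this assay only modestly, as a 1.3-fold lower number from compound 1 to compound 3 (0.13 log units; within the scatter) expresses. Compound 3 is estimated at 2000 nM, within a range from 500 nM to 8000 nM.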

Compound 3, half-maximal inhibitory concentration: 1110 nM
Estimate against measurement, compound 3: 1.8-fold (0.26 log units) above; measured number inside the range.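

Among these compounds, this is the first step between two measured compounds, and it shows that the number responds to what sits on this amine nitrogen. In this assay, 4-ethoxyphenyl in place of benzyl gives a 2.4-fold lower number from compound 1 to compound 3 (0.38 log units; beyond the scatter). The step is modest but beyond the usual scatter, and the entering group differs from benzyl in more than one way, since it also brings an oxygen that counts as a hydrogen-bond acceptor, and no measured property here explains the step.

The compounds shown leave open whether the ethoxy group matters or whether a plain phenyl on the same nitrogen would give a similar number. They also do not show how a 4-methoxyphenyl or a 4-butoxyphenyl group, with a shorter or longer chain on the oxygen, would compare.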